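The source may hold more compounds than are shown below. What is called first, only, known or untested is meant among the compounds shown, and "the series" means these compounds.

Measured so far:
Compound 1 `COc1cc(-c2ccnc3cc(-c4ccc(C(C)(C)C)cc4)nn23)cc(OC)c1OC` — in a functional assay on MCF7 cells (Homo sapiens) for inhibition, read by CCK-8 assay, with a stated time of 48 h (on this read-out higher numbers stand for weaker inhibition and lower numbers for stronger inhibition), compound 1 gives > 10000 nM, which is a limit of the assay and not a number.
Compound 2 `COc1cc(-c2cc3nccc(-c4c[nH]c5ccccc45)n3n2)cc(OC)c1OC` — compound 2 gives > 10000 nM, likewise a limit.
Compound 3 `Cc1ccc(-c2cc3nccc(-c4ccc(F)cc4)n3n2)cc1` — compound 3 gives > 10000 nM, again a limit.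

Compound 1 thus stands at the limit of > 10000 nM in this assay, at which 3 of the 3 values shown sit; no ranking among the three is possible. Compound 4 `COc1cc(-c2ccnc3cc(-c4cccc(C)c4)nn23)cc(OC)c1OC` remains to be measured. It differs from compound 1 by 3-methylphenyl in place of 4-(tert-butyl)phenyl on an aromatic carbon. Going by the values given here, with no measured step to draw on, no movement beyond the scatter is expected in this assay, and the result is most likely another limit. Compound 4 is expected to give 15000 nM (range 5000 nM to 50000 nM), meaning an estimated step that the limit leaves unreadable from compound 1 to compound 4.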

Compound 4, half-maximal inhibitory concentration: 1080 nM
Compound 4: middle estimate off by 14-fold (1.14 log units), on the high side; the measured number lies below the stated range.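

In this assay, going by these compounds alone, this aromatic carbon of the five-membered ring proves sensitive to its aryl group: 3-methylphenyl in place of 4-(tert-butyl)phenyl gives an at least 9.2-fold lower number from compound 1 to compound 4 (0.96 log units; beyond the scatter) and the first readable number. The value of compound 1 is a limit and not a number, so the true size of the step stays unknown, and that limit remains the commonest result: the limit of > 10000 nM in this assay, at which 3 of the 4 values shown sit.

Still unseparated are the loss of the tert-butyl group, the move of the substituent on the phenyl ring, and the methyl group itself. Also open, going by these compounds, is how an amine or a carboxylic acid on that phenyl ring would read.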